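A few compounds are considered here, and "the series" means these few. Any claim that something is new, unique, unknown or untested is made for them only; others in the source may bear on it.

Series notes. Among the measured compounds shown here, compound 1 `CCN(CC)CCNC(=O)C1CC=C(C(CC)(CC)c2ccc(C#CC(C)(C)O)c(C)c2)N1CC` is the weaker of the two compounds measured so far in a functional assay on MCF7 cells (Homo sapiens) for antiproliferative activity, read by MTT assay, with a stated time of 24 h; on this read-out higher numbers stand for weaker inhibition and lower numbers for stronger inhibition: compound 1 gives 1490 nM, while compound 2 `CCN(CC)CCNC(=O)C1CC(C(CC)(CC)c2ccc(/C=C/C(O)(CC)CC)c(C)c2)=CN1CC` gives 690 nM; the two are not a single-point pair, so only their two values can be set side by side. Compound 3 `CCN(CC)CCNC(=O)C1CC=C(C(CC)(CC)c2ccc(/C=C/C(C)(O)CC)c(C)c2)N1CC` has not been measured in this assay. Its structure differs from compound 1 at one site, (a group of 7 heavy atoms (6 carbon, 1 oxygen; no ring) in place of a group of 6 heavy atoms (5 carbon, 1 oxygen; no ring), on an aromatic carbon), where the 3-hydroxy-3-methylbut-1-yn-1-yl group with its triple bond outside aromatic rings gives way to a group with a double bond outside aromatic rings, ortho to a methyl group and para to a large group. For the measured compounds named here, no measured pair tells the size of this step. Because compound 2, which also carries a double bond outside aromatic rings, gives 690 nM, a modest step toward a lower number is expected, a 1.5-fold lower number from compound 1 to compound 3 (0.17 log units; within the scatter), though it may fall within the scatter. Compound 3 is estimated at 1000 nM, with a likely range of 400 nM to 2500 nM.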

Compound 3, half-maximal inhibitory concentration: "not active" (no number reported)
Compound 3 has no reported number here, so the estimate cannot be set against anything.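

In this assay, among the compounds shown here, compound 3 is reported as not active, without a number, and no step from compound 1 to compound 3 can be read. Nothing at hand bears on this result. The compounds shown leave open how far the 3-hydroxy-3-methylbut-1-yn-1-yl group and its replacement differ in this read-out.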